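This account rests on a few compounds, and the source may have more. Where it says the series, first, only, none or still open, it means among the compounds named here.

Series notes. Compound 1 `CC(C)N(Cc1cccc(OCCCCCC(=O)O)c1)C(=O)c1ccc(-c2cccc(-c3ccccc3)c2)cc1`, compound 2 `CC(C)N(Cc1cccc(OCCCCCC(=O)O)c1)C(=O)c1ccc(-c2cccc(OCc3ccccc3)c2)cc1` and compound 3 `CCOC(=O)CCCCCOc1cccc(CN(C(=O)c2ccc(-c3cccc(-c4ccccc4)c3)cc2)C(C)C)c1` share one core and have each been run in an ADME assay on BJ cells (Homo sapiens) for cytotoxicity, read by CellTiter-Glo and resazurin assay, with a stated time of 72 h; a higher number here means that more compound is needed for the effect, a lower number that less compound is needed. For compound 1 the assay returned only a limit, > 26000 nM. For compound 2 the assay likewise returned only a limit, > 26000 nM. For compound 3 the assay again returned only a limit, > 26000 nM. The steps a step that the two limits leave unreadable from compound 1 to compound 2 and a step that the two limits leave unreadable from compound 1 to compound 3 therefore cannot be sized, since (the limit of > 26000 nM in this assay, at which 3 of the 3 values shown sit). Compound 4 `CCOC(=O)CCCCCOc1cccc(CN(C(=O)c2ccc(-c3cccc(-c4nnc(C)o4)c3)cc2)C(C)C)c1` is to be measured in this assay; the change is 5-methyl-1,3,4-oxadiazol-2-yl in place of phenyl on an aromatic carbon. Within the data shown here, no measured step bears directly on this change, and the three limits give no size to read from. The expected step that the limit leaves unreadable from compound 3 to compound 4 is accordingly placed at the limit, with no direction claimed. Compound 4 is estimated at 30000 nM, between 13000 nM and 70000 nM, most probably reported again only as a limit.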

Compound 4, half-maximal effective concentration: > 26000 nM
Compound 4: a limit, no number (the forecaster's own chance of this, stated with the estimate: 80%); the middle value is on the limit's open side.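

In this assay, among these compounds, compound 3 and compound 4 each return only a limit, and no step between them can be read. The compounds shown leave open at what concentration any of them would reach the half-maximal effect.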